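Working notes: methoxy, methyl and chloro on one shared core

A few compounds are considered here, and "the series" means these few. Any claim that something is new, unique, unknown or untested is made for them only; others in the source may bear on it.

Compound 1 `COc1ccc(Nc2nc3c(=O)[nH]c(C)nc3s2)cc1`: 36%
Compound 2 `Cc1ccc(Nc2nc3c(=O)[nH]c(C)nc3s2)cc1`: 47%

Among the measured compounds shown here, in an assay on CHO cells for displacement of a labelled ligand from adenosine receptor A3 (Homo sapiens), read by scintillation counting, with a stated time of 120 min, tested at 1 uM (on this read-out higher numbers stand for more inhibition at the one concentration tested (going by the name of the read-out) and lower numbers for less inhibition), compound 2 stands highest of the two numbers, the only step being a number 11 percentage points higher from compound 1 to compound 2 (beyond the scatter). Compound 3 `Cc1nc2sc(Nc3ccc(Cl)cc3)nc2c(=O)[nH]1` differs from compound 2 by chloro in place of methyl on an aromatic carbon. For the measured compounds named here, no measured step involves chloro, so the methyl-for-methoxy step bears only loosely on this change, and its modest size gives no direction for the new group. Compound 3 is therefore expected to sit near compound 2, with a step of a number 1 percentage points higher from compound 2 to compound 3 (within the scatter) within the scatter, estimated at 48% with a range from 28% to 68%.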

Compound 3, a percentage reported as inhibition, at one concentration (the size of the read-out at that concentration, not a potency): 49%
Estimate against measurement, compound 3: 1 percentage points below, within the range that was stated.
By their numbers in this assay, from the lowest: compound 1; then compounds 2 and 3 (each within the scatter of the next).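

At this place, on an aromatic carbon para to a large group, this assay does not separate chloro from methyl, with a number 2 percentage points higher from compound 2 to compound 3 (within the scatter). Chloro in place of methoxy gives a number 13 percentage points higher from compound 1 to compound 3 (beyond the scatter), so compound 1 now stands apart from two different replacements rather than one. Nothing available accounts for this pattern.

On these data alone, whether an amine, a carboxylic acid or a longer chain at this place would keep the number of compound 3 stays open. So does the outcome of moving chloro to another carbon of the ring.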